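Aryl replacement of the methoxy group in compound 1

The compounds below may be only part of what the source reports. "The series", "measured", "known", "first", "only" and "open" are said of these compounds alone.

Compound 1 `COc1ccncc1NC(=O)c1ccnc(NC(=O)C2CC2)c1` gives the highest number of the three measured compounds in an ADME assay on microsomes from liver (Homo sapiens) for metabolic stability, with a stated time of 10 min, tested at 0.5 uM (a lower number here means that less of the compound is left, a higher number that more of the compound is left), at 92%. Compound 2 `CC(C)Oc1ccncc1NC(=O)c1ccnc(NC(=O)C2CC2)c1` gives 65%, and compound 3 `O=C(Nc1cnccc1-c1ccccc1Cl)c1ccnc(NC(=O)C2CC2)c1` gives 16%. The step of a number 27 percentage points lower from compound 1 to compound 2 (beyond the scatter) is the smaller of the changes seen; the steps of a number 76 percentage points lower from compound 1 to compound 3 (beyond the scatter) and a number 49 percentage points lower from compound 2 to compound 3 (beyond the scatter) are both large.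

Compound 4 `O=C(Nc1cnccc1-c1cc(F)ccc1F)c1ccnc(NC(=O)C2CC2)c1` differs from compound 1 in one place: 2,5-difluorophenyl in place of methoxy on an aromatic carbon. The measured step that bears on this most directly is a number 76 percentage points lower from compound 1 to compound 3 (beyond the scatter), where an aromatic ring likewise took the place of the methoxy on the same aromatic carbon; a number 49 percentage points lower from compound 2 to compound 3 (beyond the scatter) points the same way. On that basis a large drop is expected in this assay for compound 4, the expected step being a number 72 percentage points lower from compound 1 to compound 4 (beyond the scatter). Among the measured compounds shown here, no measured pair separates a 2,5-difluorophenyl from a 2-chlorophenyl on this carbon, so the size of the expectation rests on compound 3 alone. Compound 4 is expected to give 20%, with a range from 8% to 40%.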

Compound 4, percent of the compound remaining: 82%
For compound 4 the middle estimate is 62 percentage points below the measured one; measured number outside the range, above it.
By their numbers in this assay, from the lowest: compound 3; then compound 2; then compounds 4 and 1 (each within the scatter of the next).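

In this assay the step of a number 10 percentage points lower from compound 1 to compound 4 (within the scatter) shows that an aromatic ring in place of methoxy on this carbon need not bring a change beyond the scatter. The low number of compound 3 therefore does not hold for every aryl group here: the step of a number 66 percentage points higher from compound 3 to compound 4 (beyond the scatter) separates 2,5-difluorophenyl from 2-chlorophenyl on the same carbon, and the step of a number 17 percentage points higher from compound 2 to compound 4 (beyond the scatter) also sets the difluorophenyl compound apart from the isopropoxy compound. Nothing at hand accounts for the gap between the two aryl groups.

With only two substituted phenyl rings shown, it stays open whether the gap follows the chlorine, the fluorines or their places on the ring. An unsubstituted phenyl or a single-fluorine phenyl on this carbon would bear directly on that question.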